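This account rests on a few compounds, and the source may have more. Where it says the series, first, only, none or still open, it means among the compounds named here.

Of the compounds shown here, three built on the shared core have been tested in a functional assay on Hep cells (Homo sapiens) for cytotoxicity, read by sulforhodamine B assay, with a stated time of 48 h; a higher number here means a weaker inhibitor, a lower number a stronger inhibitor. Compound 1 `C=CCOc1ccc(F)cc1C(=O)c1cccnc1` gives > 100000 nM, which is a limit of the assay rather than a number. Compound 1 therefore stands at the limit of > 100000 nM in this assay, at which 2 of the 3 values shown sit, and no number places it against the others. Compound 2 `C=CCOc1cc(Br)ccc1C(=O)c1cccnc1` gives > 100000 nM, likewise a limit. Compound 3 `O=C(c1cccnc1)c1ccccc1O`, which carries neither an allyloxy group nor a fluoro or bromo group, gives 31000 nM in this assay. No step between any two of these compounds is recorded, so the values show only that compound 3 has a number where the other two have limits. Compound 4 `C=CCOc1ccc(Br)cc1C(=O)c1cccnc1` is not yet measured. It differs from compound 1 by bromo in place of fluoro on an aromatic carbon. With compound 1 and compound 2 both sitting at a limit, no step beyond the scatter is expected from this change, and compound 4 is expected to remain at or near the limit. The expected step is a step that the limit leaves unreadable from compound 1 to compound 4. Compound 4 is estimated at 150000 nM, with a range from 50000 nM to 500000 nM.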

Compound 4, half-maximal inhibitory concentration: 78000 nM
Compound 4: middle estimate off by 1.9-fold (0.28 log units), on the high side; the measured number falls inside the stated range.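

Within the data shown here, with bromo in place of fluoro on this aromatic carbon, para to the allyloxy group, this assay returns a number for the first time among the allyloxy compounds, and the change reads as an at least 1.2-fold lower number from compound 1 to compound 4 (0.10 log units; that floor lies within the scatter). Compound 1 gives > 100000 nM, which is a limit, so only the floor of this step is known and the true size of the change stays unread. The change therefore places compound 4 on the scale but does not show a drop beyond the scatter, and the comparison still rests on a limit: the limit of > 100000 nM in this assay, at which 2 of the 4 values shown sit.

The compounds shown leave open whether chloro, an amine or a carboxylic acid on this same carbon would give a number. They also leave open whether a longer chain in place of the allyloxy group would shift the value of compound 4.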